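The source may hold more compounds than are shown below. What is called first, only, known or untested is meant among the compounds shown, and "the series" means these compounds.

Compound 1 `COc1ccc(/C=N/NC(=O)Nc2cc3c(Nc4ccc(F)c(Cl)c4)ncnc3cc2O[C@H]2CCOC2)c(OC)c1OC` carries an oxolan-3-yl group on an oxygen on an aromatic ring and a 2,3,4-trimethoxyphenyl group on a carbon with a double bond to nitrogen. In a functional assay on A549 cells (Homo sapiens) for cytotoxicity, read by MTT assay, with a stated time of 72 h (on this read-out higher numbers stand for weaker inhibition and lower numbers for stronger inhibition), compound 1 gives 25200 nM. Compound 2 `COc1cc(/C=N/NC(=O)Nc2cc3c(Nc4ccc(F)c(Cl)c4)ncnc3cc2O[C@H]2CCOC2)cc(OC)c1OC` differs from it only by 3,4,5-trimethoxyphenyl in place of 2,3,4-trimethoxyphenyl on a carbon with a double bond to nitrogen, and in this assay compound 2 gives 26400 nM, a step of a 1.0-fold higher number from compound 1 to compound 2 (0.02 log units; within the scatter). Compound 3 `COc1cc2ncnc(Nc3ccc(F)c(Cl)c3)c2cc1NC(=O)N/N=C/c1ccc(OC)c(OC)c1OC` keeps the 2,3,4-trimethoxyphenyl group of compound 1 but its core differs by methyl in place of oxolan-3-yl on an oxygen on an aromatic ring; in this assay compound 3 gives 32800 nM, a step of a 1.3-fold higher number from compound 1 to compound 3 (0.11 log units; within the scatter). All three numbers lie within the scatter of one another, so no order among them can be read.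

Compound 4 `COc1cc2ncnc(Nc3ccc(F)c(Cl)c3)c2cc1NC(=O)N/N=C/c1cc(OC)c(OC)c(OC)c1` has not yet been measured in this assay. For the measured compounds named here, it differs from compound 3 by 3,4,5-trimethoxyphenyl in place of 2,3,4-trimethoxyphenyl on a carbon with a double bond to nitrogen, which is the same change, at the same place, as the one that turned compound 1 into compound 2, here made on the core of compound 3. Going by the values given here, the only evidence for what this change does is the step from compound 1 to compound 2, which stayed within the scatter; since compound 3 gives 32800 nM, the expected step from compound 3 to compound 4 in this assay is a 1.0-fold higher number from compound 3 to compound 4 (0.02 log units; within the scatter), with the same negligible size. Compound 4 is therefore estimated at 34000 nM, likely between 17000 nM and 68000 nM.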

Compound 4, half-maximal inhibitory concentration: 32100 nM
The estimate for compound 4 lay 1.1-fold (0.02 log units) above the measured number, within the range that was stated.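

In this assay, putting 3,4,5-trimethoxyphenyl in place of 2,3,4-trimethoxyphenyl on the core of compound 3 gives a 1.0-fold lower number from compound 3 to compound 4 (0.01 log units; within the scatter), and this agrees with what the same change did on the core of compound 1: the same change on two cores in this assay, a 1.0-fold higher number (0.02 log units; within the scatter) from compound 1 to compound 2 and a 1.0-fold lower number (0.01 log units; within the scatter) from compound 3 to compound 4, 1.1-fold (0.03 log units) apart, within the scatter of two such steps

Methyl in place of oxolan-3-yl on an oxygen on an aromatic ring, with the 3,4,5-trimethoxyphenyl group kept, gives a 1.2-fold higher number from compound 2 to compound 4 (0.08 log units; within the scatter), and this also agrees with the earlier step: the same change on two cores in this assay, a 1.3-fold higher number (0.11 log units; within the scatter) from compound 1 to compound 3 and a 1.2-fold higher number (0.08 log units; within the scatter) from compound 2 to compound 4, 1.1-fold (0.03 log units) apart, within the scatter of two such steps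

For the compounds shown here, both changes thus carry from one core to the other only in the sense that each stays within the scatter on both cores; this shows that neither has a readable effect on these four compounds, but it does not show that a step of real size would carry across in the same way, since no such step occurs here.

The compounds shown leave open whether any other group on the oxygen, such as a longer chain ending in an amine, would give a number that differs beyond the scatter from those of compound 3 and compound 4. They also leave open what happens on the carbon with a double bond to nitrogen when the trimethoxyphenyl group gives way to a phenyl ring carrying a hydroxy group or a carboxylic acid.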